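Series notes: replacing the aryl-pyrazole arm of compound 3

The source may hold more compounds than are shown below. What is called first, only, known or untested is meant among the compounds shown, and "the series" means these compounds.

Three analogues of a shared core have numbers in an assay on Sf9 cells for inhibition of histone-lysine N-methyltransferase EZH2 (Homo sapiens), read by scintillation counting, in the presence of a further agent that is not named here; on this read-out lower numbers stand for stronger inhibition and higher numbers for weaker inhibition. Compound 1 `Nc1ncnc2c1ncn2[C@@H]1O[C@H](CSCC[C@H](N)C(=O)NCC2CC2)[C@@H](O)[C@H]1O` gives 60000 nM, compound 2 `Cc1ccccc1-n1cc(CNC(=O)[C@@H](N)CCSC[C@H]2O[C@@H](n3cnc4c(N)ncnc43)[C@H](O)[C@@H]2O)cn1` gives 28000 nM, and compound 3 `Nc1ncnc2c1ncn2[C@@H]1O[C@H](CSCC[C@H](N)C(=O)NCc2cnn(-c3ccc(F)cc3)c2)[C@@H](O)[C@H]1O` gives 1400 nM. Compound 3 stands lowest of the three, with steps to both others beyond the scatter, so it is the most potent measured here. The steps of a 2.1-fold lower number from compound 1 to compound 2 (0.33 log units; beyond the scatter) and a 43-fold lower number from compound 1 to compound 3 (1.63 log units; beyond the scatter) show that a larger two-ring arm in place of the cyclopropyl helps, and the step of a 20-fold lower number from compound 2 to compound 3 (1.30 log units; beyond the scatter) shows that the group carried on the aromatic nitrogen decides most of the gain.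

Compound 4 `CN1CCn2nc(CNC(=O)[C@@H](N)CCSC[C@H]3O[C@@H](n4cnc5c(N)ncnc54)[C@H](O)[C@@H]3O)cc2C1` is not yet measured. Relative to compound 3 it carries a group of 10 heavy atoms (7 carbon, 3 nitrogen; one five-membered aromatic ring with 2 hetero atoms, one six-membered non-aromatic ring with 2 hetero atoms) in place of a group of 12 heavy atoms (9 carbon, 2 nitrogen, 1 fluorine; one five-membered aromatic ring with 2 hetero atoms, one six-membered aromatic ring of carbon only), on a saturated chain carbon bound to an amide-type nitrogen. Going by the values given here, the aryl ring whose identity drove the step from compound 2 to compound 3 is gone, replaced by a fused saturated ring; no measured pair tests that change directly. A loss is therefore expected, smaller than the spread between compound 2 and compound 3, and a step of a 5.7-fold higher number from compound 3 to compound 4 (0.76 log units; beyond the scatter) is the estimate. For compound 4 the expected value is 8000 nM, with a range from 2000 nM to 35000 nM.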

Compound 4, half-maximal inhibitory concentration: 50000 nM
Compound 4: middle estimate off by 6.3-fold (0.80 log units), on the low side; the whole stated range lies below it.
By their numbers in this assay, from the lowest: compound 3; then compounds 2, 4 and 1 (each within the scatter of the next, the first and the last beyond it).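

In this assay, the step of a 36-fold higher number from compound 3 to compound 4 (1.55 log units; beyond the scatter) shows that the potency of compound 3 does not carry over to an arm in which a six-membered non-aromatic ring with 2 hetero atoms replaces the six-membered aromatic ring of carbon only. The steps of a 1.8-fold higher number from compound 2 to compound 4 (0.25 log units; within the scatter) and a 1.2-fold lower number from compound 1 to compound 4 (0.08 log units; within the scatter) both lie within the scatter, so a two-ring arm is not enough by itself: this new arm stands level with the 2-methylphenyl arm of compound 2 and with the much smaller cyclopropyl arm of compound 1. No supporting measurement accompanies this result to account for the loss.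

As far as these compounds go, compound 2 and compound 3 differ in both the substituent and its place on the phenyl ring, so the separate contributions remain open. A 2-fluorophenyl or 4-methylphenyl group on the aromatic nitrogen would separate the two.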